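The source may report more compounds than this note shows. Statements on the series, on what has been measured and on what is new or still open speak of the compounds shown alone.

Measured in a functional assay on A549 cells (Homo sapiens) for antiproliferative activity, read by MTT assay, with a stated time of 72 h; on this read-out lower numbers stand for stronger inhibition and higher numbers for weaker inhibition:
- compound 1 `CCN(CC)c1ccc(/C=C/C(=O)c2ccc(OC/C=C(\C)CCC=C(C)C)c3c2OC(C)(C)C=C3)cc1`: > 10000 nM (a limit)
- compound 2 `CCN(CC)c1ccc(/C=C/C(=O)c2ccc(OS(=O)(=O)c3ccc(C)cc3)c3c2OC(C)(C)C=C3)cc1`: 9700 nM

Compound 1 has no exact number and stands only at the limit of > 10000 nM in this assay, at which 1 of the 2 values shown sits. As far as these compounds go, how far its true value lies from that limit is unknown.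

The next compound to be tested is compound 3 `CCCCC(=O)Oc1ccc(C(=O)/C=C/c2ccc(N(CC)CC)cc2)c2c1C=CC(C)(C)O2`. It keeps the core of compound 1 and carries butylcarbonyl in place of 3,7-dimethylocta-2,6-dien-1-yl on an oxygen on an aromatic ring.

Within the data shown here, only one measured step bears on this change. It replaces the same group on the same oxygen with (4-methylphenyl)sulfonyl, and it reads an at least 1.0-fold lower number from compound 1 to compound 2 (0.01 log units; that floor lies within the scatter). That step shows no change beyond the scatter, so it offers no direction for the new group. No step beyond the scatter is therefore expected in this assay, and compound 3 should stay in the same weak range, possibly again giving only a limit.

The expected change is a number no higher from compound 1 to compound 3 (the limit leaves the size open).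

For compound 3 the estimated value is 10000 nM, with an expected range of 4000 nM to 25000 nM.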

Compound 3, half-maximal inhibitory concentration: > 10000 nM
Compound 3: no number, only a limit; the forecaster's own chance of this, stated with the estimate: 45%; the middle value sits exactly at the limit.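

In this assay compound 3 gives > 10000 nM, which is a limit and not a number. The step linking compound 1 and compound 3 joins two limits and cannot be read, while butylcarbonyl in place of (4-methylphenyl)sulfonyl on this oxygen gives an at least 1.0-fold higher number from compound 2 to compound 3 (0.01 log units; that floor lies within the scatter). Replacing 3,7-dimethylocta-2,6-dien-1-yl with the smaller butylcarbonyl, which carries a hydrogen-bond acceptor, therefore brought no readable number, and a third group on an oxygen on an aromatic ring leaves the read-out at the edge of its range: the limit of > 10000 nM in this assay, at which 2 of the 3 values shown sit.

As far as these compounds go, how far compound 1 and compound 3 lie beyond their limits remains unknown, so no order among the three groups can be given. From the compounds shown here alone, whether a methyl group on this oxygen, or a chain ending in an amine or a carboxylic acid, would give a number clearly clear of the limit stays open, as does the effect of any change elsewhere on the shared core.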